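This account rests on a few compounds, and the source may have more. Where it says the series, first, only, none or still open, it means among the compounds named here.

Measured in a functional assay on PC-12 cells (Rattus norvegicus) for inhibition, read by sulforhodamine B assay; a higher number here means a weaker inhibitor, a lower number a stronger inhibitor:
compound 1 `O=C1NC(=O)C(Cc2ccc(OCC3CCCCO3)cc2)S1`: > 100000 nM
compound 2 `O=C1N=C(O)S/C1=C\c1ccc(OCC2CCCCO2)cc1`: 22000 nM

Compound 1 stands at > 100000 nM, which is a limit of this assay and not a number. All that can be said of it is where the reading stopped. Compound 2, by contrast, gives a true number, 22000 nM.

The next compound to consider is compound 3 `CCC(C)(C)Oc1ccc(CC2SC(=O)NC2=O)cc1`. It keeps the core of compound 1 and alters one group only: 1,1-dimethylpropyl in place of (oxan-2-yl)methyl on an oxygen on an aromatic ring. The group that enters has no ring and no hydrogen-bond acceptor, while the one that leaves has a six-membered non-aromatic ring holding its single acceptor. For the measured compounds named here, no measured pair here shows what such a swap does in this assay, so any forecast is cautious. The expected step, an at least 1.1-fold lower number from compound 1 to compound 3 (0.04 log units; that floor lies within the scatter), is a modest one towards a lower number, if it appears at all. It is quite possible that compound 3 will again return only a limit. For compound 3 the estimated value is about 90000 nM, with an expected range from 25000 nM to 300000 nM.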

Compound 3, half-maximal inhibitory concentration: 23000 nM
Compound 3: middle estimate off by 3.9-fold (0.59 log units), on the high side, and the stated range ends above it.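

In this assay, replacing (oxan-2-yl)methyl with 1,1-dimethylpropyl on the oxygen gives an at least 4.3-fold lower number from compound 1 to compound 3 (0.63 log units; beyond the scatter). For the compounds shown here, this is the first sign that the group at this place can move the reading, and the step is beyond the usual scatter. Its true size cannot be read, because compound 1 gives a limit and not a number, so only a minimum for the step is known: the limit of > 100000 nM in this assay, at which 1 of the 3 values shown sits. With the shared core kept, compound 3 also shows that a true reading can be reached with a group that has no ring and no hydrogen-bond acceptor.

The swap changes the ring, the acceptor and the heavy-atom count all at once, so the compounds shown cannot tell which of these differences goes with the lower number. As far as these compounds go, a cyclohexylmethyl group would keep the ring without its oxygen, and a straight pentyl chain would keep the open shape without the branching, so either could help to separate these differences, and how far the number can fall at this place remains open.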